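From 2-chlorobenzyl to 2-bromobenzyl

A few compounds are considered here, and "the series" means these few. Any claim that something is new, unique, unknown or untested is made for them only; others in the source may bear on it.

Compound 1 `COc1cc(OC)c(-c2coc3cc(OCc4ccccc4C)ccc3c2=O)cc1OC` gives 2150 nM
Compound 2 `COc1cc(OC)c(-c2coc3cc(OCc4ccc(Cl)cc4)ccc3c2=O)cc1OC` gives 2400 nM
Compound 3 `COc1cc(OC)c(-c2coc3cc(OCc4ccccc4Cl)ccc3c2=O)cc1OC` gives 4180 nM

In a functional assay on B16 cells (Mus musculus) for antiproliferative activity, read by MTT assay, with a stated time of 24 h (a higher number here means a weaker inhibitor, a lower number a stronger inhibitor), compound 3 stays within the scatter of both others, with a 1.7-fold higher number from compound 2 to compound 3 (0.24 log units; within the scatter) and a 1.9-fold higher number from compound 1 to compound 3 (0.29 log units; within the scatter) as its steps. Compound 4 `COc1cc(OC)c(-c2coc3cc(OCc4ccccc4Br)ccc3c2=O)cc1OC` has not yet been measured. Its difference is bromo in place of chloro on an aromatic carbon in all, bromo in place of chloro on an aromatic carbon. For the measured compounds named here, the closest precedent is the second step above, chloro in place of methyl on an aromatic carbon, and it stayed within the scatter. So did the first, which moved the chloro. No change beyond the scatter is therefore expected, and the estimated step is a 1.3-fold lower number from compound 3 to compound 4 (0.10 log units; within the scatter) in size. For compound 4 the expected value is 3300 nM with 1700 nM to 6500 nM as its estimated range.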

Compound 4, half-maximal inhibitory concentration: 8900 nM
The estimate for compound 4 lay 2.7-fold (0.43 log units) below the measured number; the whole stated range lies below it.
By their numbers in this assay, from the lowest: compounds 1, 2 and 3 (each within the scatter of the next); then compound 4.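

For the compounds shown here, at this aromatic carbon, the exchange of chloro for bromo is the first change to leave the scatter: this assay shows a 2.1-fold higher number from compound 3 to compound 4 (0.33 log units; beyond the scatter) as the step, while methyl to chloro stayed within it. Bromo in place of methyl gives a 4.1-fold higher number from compound 1 to compound 4 (0.62 log units; beyond the scatter) and 2-bromophenyl in place of 4-chlorophenyl gives a 3.7-fold higher number from compound 2 to compound 4 (0.57 log units; beyond the scatter) as steps, so compound 4 is the weakest of the four. From the compounds shown here alone, whether a fluoro or an iodo group at this place would stand with compound 3 or with compound 4 stays open. Nothing measured here offers a reason for the shift.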